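Swapping 3-hydroxybenzyl for 4-nitrophenyl on compound 1

The source may report more compounds than this note shows. Statements on the series, on what has been measured and on what is new or still open speak of the compounds shown alone.

Among the measured compounds shown here, in an ADME assay on HEK-293T cells (Homo sapiens) for cytotoxicity, read by CCK-8 assay, with a stated time of 48 h (a higher number here means a weaker inhibitor, a lower number a stronger inhibitor), compound 1 (`O=S(=O)(NCCNC(=S)Nc1cccc(Cl)c1)c1ccc(-c2ccccc2OCc2cccc(O)c2)s1`) gives 17400 nM as the only true number among the measured compounds. Compound 2 (`O=[N+]([O-])c1ccc(NC(=S)NCCNS(=O)(=O)c2ccc(-c3ccccc3OCc3cccc(O)c3)s2)cc1`) reads > 20000 nM and this is a limit of the assay. Compound 3 (`Cc1cc(C)cc(NC(=O)NCCNS(=O)(=O)c2ccc(-c3ccccc3OCc3cccc(O)c3)s2)c1`) reads > 20000 nM and this is also a limit.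

Compound 4 (`O=[N+]([O-])c1ccc(Oc2ccccc2-c2ccc(S(=O)(=O)NCCNC(=S)Nc3cccc(Cl)c3)s2)cc1`) differs from compound 1 by 4-nitrophenyl in place of 3-hydroxybenzyl on an oxygen on an aromatic ring and so carries 4-nitrophenyl in place of 3-hydroxybenzyl on an oxygen on an aromatic ring. Neither measured step from compound 1 touches that oxygen. The first, an at least 1.1-fold higher number from compound 1 to compound 2 (0.06 log units; that floor lies within the scatter), places 4-nitrophenyl on an amide-type nitrogen instead. The second, an at least 1.1-fold higher number from compound 1 to compound 3 (0.06 log units; that floor lies within the scatter), also alters a group on nitrogen. Both bear on the new change only indirectly, and neither gives a step beyond the scatter.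

With no measured change at this oxygen, the expected step is a 1.2-fold lower number from compound 1 to compound 4 (0.06 log units; within the scatter) and no larger than the scatter. For compound 4 the estimated value is 15000 nM with an expected range of 6500 nM to 25000 nM in this measurement.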

Compound 4, half-maximal inhibitory concentration: 4990 nM
Compound 4: middle estimate off by 3.0-fold (0.48 log units), on the high side; measured number below the stated range.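

Among the compounds shown here, replacing 3-hydroxybenzyl with 4-nitrophenyl on this oxygen gives a 3.5-fold lower number from compound 1 to compound 4 (0.54 log units; beyond the scatter), the first step that lies beyond the scatter. It shows that in this assay the group on this oxygen can move the number, and downward, towards a stronger inhibitor. The earlier steps changed a group on nitrogen and gave only floors, since their end points are limits of the assay and not numbers: the limit of > 20000 nM in this assay, at which 2 of the 4 values shown sit.

The swap removes the hydroxyl and the benzyl carbon and adds the nitro group in one step, so the compounds shown cannot say which of these changes matters. From the compounds shown here alone, a plain phenyl group on this oxygen, or an amine in place of the nitro group, remains open, as does whether the swap would act the same way on a different group on nitrogen.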